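Swapping the Oxadiazole for a Six-Membered Ring

The source may report more compounds than this note shows. Statements on the series, on what has been measured and on what is new or still open speak of the compounds shown alone.

In an ADME assay on cells (Hepatocyte, Rattus norvegicus) for metabolic stability (a higher number here means that the compound lasts longer, a lower number that the compound disappears faster), compound 3 `Cc1nnc(N2CCC(C(=O)N3N=CC[C@H]3c3cc(F)cc(F)c3)CC2)o1` gives 3.3 h. In the same test, compound 2 `Cc1nnc(N2CCC(C(=O)N3N=CC[C@H]3c3ccccc3)CC2)o1` gives 2.88 h. Replacing phenyl with 3,5-difluorophenyl makes a 1.1-fold higher number from compound 2 to compound 3 (0.06 log units; within the scatter), so these two compounds stand level. Compound 1 `O=C(C1CCN(c2ccncn2)CC1)N1N=CC[C@H]1c1ccccc1` reports only a limit, < 0.4 h.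

Compound 4 `N#Cc1cc(N2CCC(C(=O)N3N=CC[C@H]3c3cc(F)cc(F)c3)CC2)ncn1` keeps the rest of compound 3 and alters one group: a group of 8 heavy atoms (5 carbon, 3 nitrogen; one six-membered aromatic ring with 2 hetero atoms) in place of a group of 6 heavy atoms (3 carbon, 2 nitrogen, 1 oxygen; one five-membered aromatic ring with 3 hetero atoms), on an amine nitrogen in a ring. The best guide is the earlier change on that same amine nitrogen, where 5-methyl-1,3,4-oxadiazol-2-yl took the place of pyrimidin-4-yl. That swap gave an at least 7.2-fold higher number from compound 1 to compound 2 (0.85 log units; beyond the scatter). Compound 4 runs roughly the opposite way, since its new group also holds a six-membered aromatic ring with 2 hetero atoms. The match is imperfect, however, as the new group also has a triple bond outside aromatic rings, which compound 1 lacks. The 3,5-difluorophenyl group offers little counterweight, given the small size of the step to compound 3 shown above. A fall beyond the scatter is therefore expected, and the estimated size is a 4.7-fold lower number from compound 3 to compound 4 (0.67 log units; beyond the scatter). The expected half-life of compound 4 is 0.7 h, within an estimated range from 0.25 h to 2 h.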

Compound 4, half-life: 1.15 h
Compound 4: the middle estimate sits 1.6-fold (0.22 log units) below what was measured; the measured number falls inside the stated range.
By their numbers in this assay, from the lowest: compound 4; then compounds 2 and 3 (each within the scatter of the next). At a limit, below all of these: compound 1.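

Compound 1 stands at a limit, so the earlier change on this amine nitrogen could give only a minimum size: the limit of < 0.4 h in this assay, at which 1 of the 4 values shown sits.

The new pair has a measured number at both ends, and in this assay it puts a definite size on a change of this kind: a 2.9-fold lower number from compound 3 to compound 4 (0.46 log units; beyond the scatter). It also carries the direction over to compounds with 3,5-difluorophenyl, so in both pairs that differ on this nitrogen, one with phenyl and one with 3,5-difluorophenyl, the compound holding 5-methyl-1,3,4-oxadiazol-2-yl has the higher number, and none of the four compounds goes against this.

The entering group is more than a six-membered aromatic ring with 2 hetero atoms, since it also has a nitrile, and no pair shown separates the share of the nitrile from the share of the ring that carries it. On these data alone, how other groups on this amine nitrogen, such as an acetyl group or a plain pyridine ring, would compare with the 5-methyl-1,3,4-oxadiazol-2-yl group also remains open.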